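Macrocyclic lactam chalcones: aryl change on the enone

A few compounds are considered here, and "the series" means these few. Any claim that something is new, unique, unknown or untested is made for them only; others in the source may bear on it.

Measured so far:
compound 1 `COc1cc(/C=C/C(=O)c2ccc(OCCn3cc(CN4C(=O)/C=C/C(C)(C)C/C=C(\C)CC/C=C/4C)nn3)cc2O)cc(OC)c1OC`: 1.44 ug/mL
compound 2 `COc1ccc(/C=C/C(=O)c2ccc(OCCCN3C(=O)/C=C/C(C)(C)C/C=C(\C)CC/C=C/3C)cc2)cc1`: 1.73 ug/mL

In a functional assay on HepG2 cells (Homo sapiens) for antiproliferative activity (a higher number here means a weaker inhibitor, a lower number a stronger inhibitor), compound 2 gives 1.73 ug/mL. Compound 1 gives 1.44 ug/mL in this assay, a gap that lies within the usual scatter, so the two compounds are not separated by the numbers at hand. Compound 3 `COc1cc(/C=C/C(=O)c2ccc(OCCCN3C(=O)/C=C/C(C)(C)C/C=C(\C)CC/C=C/3C)cc2)cc(OC)c1OC` is not yet measured. It differs from compound 2 by 3,4,5-trimethoxyphenyl in place of 4-methoxyphenyl on a double-bonded chain carbon bound to a double-bonded chain carbon. Among the measured compounds shown here, no step between measured compounds isolates this change. The expected move from compound 2 to compound 3 in this assay is a 1.3-fold lower number from compound 2 to compound 3 (0.12 log units; within the scatter), i.e. none beyond the scatter. Compound 3 is estimated at 1.3 ug/mL, within 0.5 ug/mL to 3.5 ug/mL.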

Compound 3, half-maximal inhibitory concentration: 0.99 ug/mL
For compound 3 the middle estimate is 1.3-fold (0.12 log units) above the measured one; low and high end bracket the measured number.
By their numbers in this assay, from the lowest: compounds 3, 1 and 2 (each within the scatter of the next).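

Among the compounds shown here, this is the first step that isolates the aryl group on a double-bonded chain carbon bound to a double-bonded chain carbon: in this assay, 3,4,5-trimethoxyphenyl in place of 4-methoxyphenyl gives a 1.7-fold lower number from compound 2 to compound 3 (0.24 log units; within the scatter) with the rest of the structure unchanged. The two extra methoxy groups therefore do not separate the compounds at this place. No supporting data bear on the origin of this step.

From the compounds shown here alone, whether a 4-dimethylaminophenyl or 4-carboxyphenyl group at this place would move the number beyond the scatter remains open. No pair shown isolates a change in the chain attached to the ring nitrogen.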